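The source may report more compounds than this note shows. Statements on the series, on what has been measured and on what is new or still open speak of the compounds shown alone.

Measured so far in the series:
compound 1 `COc1ccccc1/C=C/C(=O)/C=C/c1ccc(OCc2cn(CCCCOc3cc(=O)oc4ccccc34)nn2)c(OC)c1` — "not active" (no number reported)
compound 2 `COc1cc(/C=C/C(=O)/C=C/c2cccc3ccccc23)ccc1OCc1cn(CCCOc2cc(=O)oc3ccccc23)nn1` — 8%
compound 3 `COc1cc(/C=C/C(=O)/C=C/c2ccco2)ccc1OCc1cn(CCCCOc2cc(=O)oc3ccccc23)nn1` — "not active" (no number reported)

In a functional assay on PC-3 cells (Homo sapiens) for inhibition, read by sulforhodamine B assay, with a stated time of 48 h, tested at 50 uM (on this read-out higher numbers stand for more inhibition of growth at the one concentration tested and lower numbers for less inhibition of growth), compound 3 is recorded as "not active" (no number reported), with no number attached. Compound 1 shares that outcome and is recorded as "not active" (no number reported). Compound 2 gives 8%, a figure that sits low on this read-out. Compound 3 therefore stands at the weak end of what has been measured, and none of the three measured compounds has produced a value that clears the usual scatter with any margin.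

Compound 4 `COc1ccc(/C=C/C(=O)/C=C/c2ccc(OCc3cn(CCCCOc4cc(=O)oc5ccccc45)nn3)c(OC)c2)cc1OC` has not been measured. It differs from compound 3 by 3,4-dimethoxyphenyl in place of furan-2-yl on a double-bonded chain carbon bound to a double-bonded chain carbon. Within the data shown here, no measured pair differs in one place, so there is no step to lean on for this change. With all three measured compounds weak in this assay, any move from compound 3 to compound 4 is expected to be small, most likely none beyond the scatter, and the data do not settle its direction. Compound 4 is expected to give about 10% in this assay, within a range from 0% to 30%, and a report without a numerical value is about as likely as a number.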

Compound 4, percent growth inhibition at one concentration: "not active" (no number reported)
Nothing numeric was reported for compound 4; the estimate stays without a comparison.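

Compound 3 and compound 4 both stand without a number in this assay, so no step can be read for the change from furan-2-yl to 3,4-dimethoxyphenyl. The compounds shown leave open whether this change alters growth inhibition at all, and in which direction. No evidence at hand bears on this result.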